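Amide chain lengthening in one series: expectation for compound 4

The source may report more compounds than this note shows. Statements on the series, on what has been measured and on what is new or still open speak of the compounds shown alone.

Three measured compounds share one core and differ only in the chain on the amide nitrogen. Compound 1 `CCNC(=O)CC1CCc2cc(OC)c(OC)cc21` gives 20.4% in a functional assay on the whole organism (strain Wistar) for inhibition, with Rattus norvegicus as the target, read by paw edema, with stated times of 60 min and 6 h, at a dose of 100 mg/kg by the oral route; a higher number here means more inhibition at the dose given (going by the name of the read-out), a lower number less inhibition. Compound 2 `CCCNC(=O)CC1CCc2cc(OC)c(OC)cc21` gives 22.2% in this assay, and compound 3 `CCCCCNC(=O)CC1CCc2cc(OC)c(OC)cc21` gives 35.2% in this assay.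

The steps read a number 1.8 percentage points higher from compound 1 to compound 2 (within the scatter), a number 14.8 percentage points higher from compound 1 to compound 3 (beyond the scatter) and a number 13 percentage points higher from compound 2 to compound 3 (beyond the scatter). Compound 3 stands highest of the three, its gaps to compound 2 and to compound 1 both beyond the scatter. Whether the rise continues with longer chains cannot be told from three compounds.

Compound 4 `CCCCCCNC(=O)CC1CCc2cc(OC)c(OC)cc21` is not yet measured. Its difference from compound 3 is methyl in place of hydrogen on a saturated chain carbon, five bonds along the chain from an amide-type nitrogen. The same change, made from compound 1 to compound 2, is methyl in place of hydrogen on a saturated chain carbon, two bonds along the chain from an amide-type nitrogen, and it occurs twice among the compounds shown; the step it made was a number 1.8 percentage points higher from compound 1 to compound 2 (within the scatter). The two cores differ by propyl in place of hydrogen on a saturated chain carbon, two bonds along the chain from an amide-type nitrogen. The place is not the same word for word: in one case the carbon sits two bonds along the chain from an amide-type nitrogen, in the other five bonds along the chain from an amide-type nitrogen, so this is the same kind of change rather than the same change.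

The step from compound 3 to compound 4 in this assay is expected to be small, about a number 4.8 percentage points higher from compound 3 to compound 4 (within the scatter), resting on the within-scatter step a number 1.8 percentage points higher from compound 1 to compound 2 (within the scatter) and the modest gain a number 14.8 percentage points higher from compound 1 to compound 3 (beyond the scatter). Compound 4 is thus estimated at 40%, with a range from 27% to 53%.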

Compound 4, a percentage reported as inhibition, in the whole organism at one dose (the size of the read-out at that dose, not a potency): 38.3%
Compound 4: the middle estimate sits 1.7 percentage points above what was measured, within the range that was stated.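

In this assay, methyl in place of hydrogen gives a number 3.1 percentage points higher from compound 3 to compound 4 (within the scatter), and this step carries over from the shorter chain with no difference beyond the scatter: the same change on two cores in this assay, a number 1.8 percentage points higher (within the scatter) from compound 1 to compound 2 and a number 3.1 percentage points higher (within the scatter) from compound 3 to compound 4, 1.3 percentage points apart, within the scatter of two such steps

Propyl in place of hydrogen gives a number 16.1 percentage points higher from compound 2 to compound 4 (beyond the scatter), and it carries over in the same way: the same change on two cores in this assay, a number 14.8 percentage points higher (beyond the scatter) from compound 1 to compound 3 and a number 16.1 percentage points higher (beyond the scatter) from compound 2 to compound 4, 1.3 percentage points apart, within the scatter of two such steps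

Across the whole set of chains, the butyl in place of hydrogen gives a number 17.9 percentage points higher from compound 1 to compound 4 (beyond the scatter), but the agreement rests on only two pairs of steps within this one amide series, so it does not show that these steps would hold on a different core, and it gives no reason for the gains.

With the step from compound 3 to compound 4 inside the scatter, the compounds shown leave open whether the gain seen with the lengthening chain goes on or has come to an end, which a longer chain such as octyl or decyl would help to settle. Also open, going by these compounds, is how a branched chain such as isopropyl, a ring-bearing group such as benzyl or cyclohexyl, or a chain ending in an amine or a carboxylic acid would read on the shared core.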